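From compound 2 to compound 4: one aryl group exchanged

The compounds below may be only part of what the source reports. "The series", "measured", "known", "first", "only" and "open" are said of these compounds alone.

In a functional assay on HepG2 cells (Homo sapiens) for inhibition, read by MTT assay, with a stated time of 72 h, tested at 50 uM (on this read-out higher numbers stand for more inhibition of growth at the one concentration tested and lower numbers for less inhibition of growth), compound 1 (`C=CCc1ccc(OCc2cn(-c3cccc([N+](=O)[O-])c3)nn2)c(O)c1`) gives 30.2%, compound 2 (`C=CCc1ccc(OCc2cn(-c3ccc(C#N)cc3)nn2)c(O)c1`) gives 12.1% and compound 3 (`C=CCc1ccc(OCc2cn(-c3cc(OC)c(OC)c(OC)c3)nn2)c(O)c1`) gives 2.5%. Compound 2 thus lies within the scatter of compound 3 and beyond the scatter under compound 1. Compound 4 (`C=CCc1ccc(OCc2cn(-c3ccccc3CO)nn2)c(O)c1`) carries 2-(hydroxymethyl)phenyl in place of 4-cyanophenyl on an aromatic nitrogen. Among the measured compounds shown here, no measured pair shows this exchange on its own, so the only guide is the spread of the three values, which sets a wide range. The expected step of a number 1.9 percentage points higher from compound 2 to compound 4 (within the scatter) is none beyond the scatter, in neither direction. For compound 4 the estimated value is 14%, with an expected range from 2% to 32%.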

Compound 4, percent growth inhibition at one concentration: 8.5%
Beside the measured number, compound 4's estimate is 5.5 percentage points above it; the measured number falls inside the stated range.
By their numbers in this assay, from the lowest: compounds 3, 4 and 2 (each within the scatter of the next); then compound 1.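

Among the compounds shown here, the step of a number 3.6 percentage points lower from compound 2 to compound 4 (within the scatter), with 2-(hydroxymethyl)phenyl in place of 4-cyanophenyl on an aromatic nitrogen, is the first single-place comparison. At this position, a ring without the nitrile and with a hydrogen-bond donor gives no step beyond the scatter, and the donor-bearing group also shifts the substituent to a different ring position, so the two changes are not separated here. On these data alone, whether an amine or a carboxylic acid on this aryl ring would give a step beyond the scatter stays open. Nothing available explains the result.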